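The source may report more compounds than this note shows. Statements on the series, on what has been measured and on what is new or still open speak of the compounds shown alone.

Compound 1 `O=c1[nH]c2ccc(Cl)cc2n1Cc1c(F)cccc1F` carries a hydrogen on an aromatic nitrogen of its shared core. In an ADME assay on MT4 cells (Homo sapiens) for cytotoxicity (on this read-out higher numbers stand for lower toxicity in this test and lower numbers for higher toxicity in this test), compound 1 gives > 424000 nM, which is a limit of the assay rather than a number. Compound 2 `CC(=O)n1c(=O)n(Cc2c(F)cccc2F)c2cc(Cl)ccc21` replaces that hydrogen with an acetyl (acetyl in place of hydrogen on an aromatic nitrogen). In this assay compound 2 gives > 5950 nM, again a limit. The step that the two limits leave unreadable from compound 1 to compound 2 therefore cannot be sized, because both ends sit at limits, the limit of > 424000 nM in this assay, at which 1 of the 3 values shown sits, and (the limit of > 5950 nM in this assay, at which 1 of the 3 values shown sits). Compound 3 `Cc1cc(C)cc(Cn2c(=O)[nH]c3ccc(Cl)cc32)c1` has a different side arm on the core; the difference between its core arrangement and that of compound 1 is not broken down here. In this assay, for the measured compounds named here, compound 3 gives 8900 nM, the only plain number among the three. Compound 4 `CC(=O)n1c(=O)n(Cc2cc(C)cc(C)c2)c2cc(Cl)ccc21` is not yet measured; it arises from compound 3 by the same change (acetyl in place of hydrogen on an aromatic nitrogen), an acetyl in place of hydrogen on the same kind of aromatic nitrogen. Since the earlier step stays unreadable, the expected step of a 1.1-fold higher number from compound 3 to compound 4 (0.05 log units; within the scatter) rests mainly on compound 3 giving 8900 nM and on the absence of any readable shift. Compound 4 is thus expected to give about 10000 nM, between 3000 nM and 40000 nM.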

Compound 4, half-maximal cytotoxic concentration: 7180 nM
Compound 4: middle estimate off by 1.4-fold (0.14 log units), on the high side; measured number inside the range.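

In this assay, acetyl in place of hydrogen on an aromatic nitrogen gives a 1.2-fold lower number from compound 3 to compound 4 (0.09 log units; within the scatter), so on the core and side arm of compound 3 this change leaves the read-out inside the usual scatter of repeated measurements. For the same change on the core of compound 1, the entry for compound 1 is a limit of the assay and not a number: the limit of > 424000 nM in this assay, at which 1 of the 4 values shown sits. The entry for compound 2 is also a limit, so the step on that core cannot be read, and the result does not show that the change behaves alike on both cores: the limit of > 5950 nM in this assay, at which 1 of the 4 values shown sits.

On these data alone, a single readable step supports no rule for the series, and whether the change stays inside the scatter on any other side arm remains open. Also open, as far as these compounds go, is what would be seen on the same aromatic nitrogen with a methyl, a longer chain ending in an amine, or a carboxylic acid in place of the acetyl.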